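The source may report more compounds than this note shows. Statements on the series, on what has been measured and on what is new or still open speak of the compounds shown alone.

Among the measured compounds shown here, in a functional assay on MCF7 cells (Homo sapiens) for cytotoxicity, read by MTT assay, with stated times of 3 h and 24 h (on this read-out lower numbers stand for stronger inhibition and higher numbers for weaker inhibition), compound 1 (`COc1ccc(C2=[N+]3C(=Nc4c(-c5ccccc5)c5c(n4[B-]3(F)F)-c3ccc(OC)cc3CC5)C(c3ccccc3)=C2Br)cc1`) gives 4500 nM, the only true number so far. For the measured compounds named here, its sole measured partner is compound 2 (`COc1ccc2c(c1)CCc1c(-c3ccccc3)c3n(c1-2)[B-](F)(F)[N+]1=C(c2ccc(C)s2)C(Br)=C(c2ccccc2)C1=N3`), which carries 5-methylthiophen-2-yl in place of 4-methoxyphenyl on a carbon with a double bond to nitrogen. Compound 2 reads > 25000 nM, which is a limit of the assay and not a number. That exchange makes an at least 5.5-fold higher number from compound 1 to compound 2 (0.74 log units; beyond the scatter), a step beyond the scatter.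

Compound 3 (`COc1ccc(C2=[N+]3C(=Nc4c(-c5ccccc5)c5c(n4[B-]3(F)F)-c3ccc(OC)cc3CC5)C(c3ccccc3)=C2I)cc1`) departs from compound 1 at another place: iodo in place of bromo on a double-bonded ring carbon. Going by the values given here, the single measured step leaves this halogen untouched, so it offers no direct guide to the exchange and shows only that a change elsewhere on compound 1 can matter, with an at least 5.5-fold higher number from compound 1 to compound 2 (0.74 log units; beyond the scatter). No step beyond the scatter is therefore expected in this assay, and no direction is favoured. The expected change is a 1.1-fold lower number from compound 1 to compound 3 (0.05 log units; within the scatter). The estimate for compound 3 is 4000 nM, with an expected range from 1500 nM to 12000 nM.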

Compound 3, half-maximal inhibitory concentration: 140 nM
Compound 3: middle estimate off by 29-fold (1.46 log units), on the high side; measured number outside the range, below it.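

In this assay the exchange of iodo for bromo on this double-bonded ring carbon gives a 32-fold lower number from compound 1 to compound 3 (1.51 log units; beyond the scatter) and so counts as a large step. Among the compounds shown here, the only earlier step changed the group on the carbon with a double bond to nitrogen and went to a higher number, whereas this one leaves that 4-methoxyphenyl group in place and shows that the halogen position alone can move the number far, and in the lower direction. The exchange swaps one heavy atom for one heavy atom, with no ring, hydrogen-bond donor, hydrogen-bond acceptor or net charge entering or leaving, and nothing measured here gives a cause for so large a step.

With only bromo and iodo shown at this carbon, the compounds leave open how chloro, or a small chain such as methyl, would read there, so no trend across substituents can be drawn from this single pair. They also leave open whether iodo would lower the number to a similar extent with 5-methylthiophen-2-yl in place of 4-methoxyphenyl.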